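Moving from 4-(trifluoromethyl)phenyl to 3-fluorophenyl on the sulfonyl sulfur

This account rests on a few compounds, and the source may have more. Where it says the series, first, only, none or still open, it means among the compounds named here.

In a functional assay on LOX IMVI cells (Homo sapiens) for cytotoxicity, read by MTT assay, with a stated time of 24 h (on this read-out lower numbers stand for stronger inhibition and higher numbers for weaker inhibition), compound 1 `COc1cc(-c2nc(-c3ccccc3)[nH]c2-c2ccnc(NCCCNS(=O)(=O)c3ccccc3)n2)ccc1F` gives 4520 nM, compound 2 `COc1cc(-c2nc(-c3ccccc3)[nH]c2-c2ccnc(NCCCNS(=O)(=O)c3ccc(Br)cc3)n2)ccc1F` gives 33900 nM and compound 3 `COc1cc(-c2nc(-c3ccccc3)[nH]c2-c2ccnc(NCCCNS(=O)(=O)c3ccc(C(F)(F)F)cc3)n2)ccc1F` gives 75200 nM. Compound 3 thus has the highest number of the three and is the weakest inhibitor among them. Bromo in place of hydrogen on an aromatic carbon gives a 7.5-fold higher number from compound 1 to compound 2 (0.88 log units; beyond the scatter). Trifluoromethyl in place of hydrogen gives a 17-fold higher number from compound 1 to compound 3 (1.22 log units; beyond the scatter), and trifluoromethyl in place of bromo gives a 2.2-fold higher number from compound 2 to compound 3 (0.35 log units; beyond the scatter). Both substituted compounds therefore lie above compound 1, and none of the three goes against that.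

Compound 4 `COc1cc(-c2nc(-c3ccccc3)[nH]c2-c2ccnc(NCCCNS(=O)(=O)c3cccc(F)c3)n2)ccc1F` carries 3-fluorophenyl in place of 4-(trifluoromethyl)phenyl on a sulfonyl sulfur. Among the measured compounds shown here, no measured compound carries fluoro, so the size of this step is uncertain. The trifluoromethyl leaves, and its entry gave a 17-fold higher number from compound 1 to compound 3 (1.22 log units; beyond the scatter), so much of that large step should be reversed, though probably not all of it. The expected change is a 7.5-fold lower number from compound 3 to compound 4 (0.88 log units; beyond the scatter). For compound 4 the estimated value is 10000 nM, with an expected range of 3000 nM to 35000 nM.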

Compound 4, half-maximal inhibitory concentration: 900 nM
Estimate against measurement, compound 4: 11-fold (1.05 log units) above; the measured number lies below the stated range.
By their numbers in this assay, from the lowest: compound 4; then compound 1; then compound 2; then compound 3.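

In this assay, compound 4 shows that a substituent on the phenyl carried by the sulfonyl sulfur can lower the number as well as raise it: the added fluoro gives a 5.0-fold lower number from compound 1 to compound 4 (0.70 log units; beyond the scatter). Compounds 2 and 3 had shown only rises over compound 1, and compound 4 goes against that pattern. Changing 4-(trifluoromethyl)phenyl to 3-fluorophenyl gives an 84-fold lower number from compound 3 to compound 4 (1.92 log units; beyond the scatter), and changing 4-bromophenyl to 3-fluorophenyl gives a 38-fold lower number from compound 2 to compound 4 (1.58 log units; beyond the scatter), so both steps carry past compound 1 rather than merely returning to it.

Compound 4 differs from compounds 2 and 3 in both the substituent and its place on the phenyl, and the compounds shown cannot separate these two changes or say how an amine or a methoxy group there would read. Nothing measured here explains the result.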